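The source may report more compounds than this note shows. Statements on the series, on what has been measured and on what is new or still open speak of the compounds shown alone.

Three hydroxamic acids have been measured in a physicochemical assay for solubility, at pH 7.4; on this read-out lower numbers stand for lower solubility and higher numbers for higher solubility. Compound 2 `O=C(/C=C/c1ccc(/C=C/C(=O)c2ccccc2)cc1)NO` gives 3000 nM, and compound 1 `CN1CCN(c2ccc(C(=O)/C=C/c3ccc(/C=C/C(=O)NO)cc3)cc2)CC1` gives 1000 nM. The step of a 3.0-fold lower number from compound 2 to compound 1 (0.48 log units; beyond the scatter) follows from 4-methylpiperazin-1-yl in place of hydrogen on an aromatic carbon. Compound 3 `O=C(/C=C/c1cccc(/C=C/C(=O)c2ccccc2)n1)NO` has a core that differs from that of compound 2 in a way that is not broken down here. In this assay compound 3 gives 16000 nM, the highest of the three numbers. Compound 4 `CN1CCN(c2ccccc2C(=O)/C=C/c2cccc(/C=C/C(=O)NO)n2)CC1` has not yet been measured; it differs from compound 3 by 4-methylpiperazin-1-yl in place of hydrogen on an aromatic carbon, a change of the same kind as that from compound 2 to compound 1, though here the entering group sits ortho to a large group rather than para to one. Because the earlier step was a 3.0-fold lower number from compound 2 to compound 1 (0.48 log units; beyond the scatter), a step of about a 3.2-fold lower number from compound 3 to compound 4 (0.51 log units; beyond the scatter) is expected for the new pair. Compound 4 is therefore estimated at 5000 nM, within a range from 2000 nM to 14000 nM.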

Compound 4, solubility: 450000 nM
The estimate for compound 4 lay 90-fold (1.95 log units) below the measured number, and the stated range ends below it.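

In this assay, 4-methylpiperazin-1-yl in place of hydrogen on an aromatic carbon gave a 28-fold higher number from compound 3 to compound 4 (1.45 log units; beyond the scatter), opposite in direction to a 3.0-fold lower number from compound 2 to compound 1 (0.48 log units; beyond the scatter), so neither the size nor the direction of the step carried over from one core to the other. The two pairs differ in the core and also in the place of the entering group, which sits ortho to a large group in compound 4 but not in compound 1, so they do not show which of these differences matters. Nothing available explains the reversal.

On these data alone, it remains open how the same group would behave on each core with the place of entry held constant. Also open, as far as these compounds go, is whether a morpholine or a carboxylic acid at that place would follow compound 4 or compound 1.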